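Trimming a Terminal Vinyl to Methyl on an Ester Chain

A few compounds are considered here, and "the series" means these few. Any claim that something is new, unique, unknown or untested is made for them only; others in the source may bear on it.

Measured so far:
compound 1 `C=CCCCCCCCCC(=O)O[C@H]1[C@H](O)[C@H](n2ccc(N)nc2=O)O[C@@H]1CO` — 0.05 ug/mL
compound 2 `CCCCCCCCCCCCCCCCCCCC(=O)OC[C@H]1O[C@@H](n2ccc(N)nc2=O)[C@@H](O)[C@@H]1OC(=O)CCCCCCCCCCCCCCCCCCC` — > 10 ug/mL

Of the compounds shown here, two have been measured in a functional assay on HeLa cells (Homo sapiens) for cytotoxicity, read by cell counting, with a stated time of 48 h; a lower number here means that less compound is needed, a higher number that more compound is needed for the effect. For the measured compounds named here, compound 1 gives 0.05 ug/mL there, the only plain number in the set. For compound 2 the result is the limit of > 10 ug/mL in this assay, at which 1 of the 2 values shown sits, which is a limit of the assay rather than a measured number. Going by the values given here, compound 1 therefore stands alone as the single compound with a numerical value, while compound 2 sits at the limit. Among the compounds with values here, no two measured compounds differ in just one place, so no single structural step can be read directly from the data.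

Compound 3 `CCCCCCCCCC(=O)O[C@H]1[C@H](O)[C@H](n2ccc(N)nc2=O)O[C@@H]1CO` has not yet been measured. It differs from compound 1 as follows: methyl in place of vinyl on a saturated chain carbon, eight bonds along the chain from a carbonyl carbon. The change is small in what is counted, and it lies far out along the ester chain, eight bonds from the carbonyl carbon. Within the data shown here, no measured step informs this change, so the step from compound 1 to compound 3 in this assay is expected to stay within the usual scatter, with no clear direction: a 1.2-fold higher number from compound 1 to compound 3 (0.08 log units; within the scatter) is the expected size. Compound 3 is accordingly estimated at 0.06 ug/mL, with a range from 0.02 ug/mL to 0.2 ug/mL.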

Compound 3, concentration for half-maximal effect: 0.09 ug/mL
For compound 3 the middle estimate is 1.5-fold (0.18 log units) below the measured one, within the range that was stated.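

In this assay, the swap of vinyl for methyl on a saturated chain carbon, eight bonds along the chain from a carbonyl carbon, gives a 1.8-fold higher number from compound 1 to compound 3 (0.26 log units; within the scatter). For the compounds shown here, this is the first direct reading at this place on the ester chain, since the earlier compounds offered no pair differing in one place. Compound 1 and compound 3 cannot be told apart here, so the double bond at the chain end is not required for the cytotoxic effect in HeLa cells: the saturated chain of compound 3 serves as well. Nothing measured here bears on why the two compounds read alike.

Going by these compounds alone, the single swap tests only a small hydrocarbon change at the chain end, so it remains open how this position would respond to a polar group such as an amine or a carboxylic acid there, or to a longer chain. Compound 2 stands at > 10 ug/mL, which is a limit of the assay and not a number, and it differs from compound 1 in more than one place, so what separates it remains unresolved.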